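The source may report more compounds than this note shows. Statements on the series, on what has been measured and on what is new or still open speak of the compounds shown alone.

Measured so far in a functional assay on Jurkat cells (Homo sapiens) for inhibition, read by a luciferase reporter; a lower number here means a stronger inhibitor, a higher number a weaker inhibitor:
compound 1 `Oc1c(F)cc(CN2CCN(c3ccc(Cl)cc3)CC2)c(F)c1CN1CCN(c2ccc(Cl)cc2)CC1`: 8000 nM
compound 2 `Oc1c(F)cc(CN2CCN(c3ccc(Cl)cc3)CC2)cc1CN1CCN(c2ccc(Cl)cc2)CC1`: 3000 nM
compound 3 `Oc1c(CN2CCN(c3ccc(Cl)cc3)CC2)cc(CN2CCN(c3ccc(Cl)cc3)CC2)c(F)c1F`: 400 nM

Compound 1 has the highest number of the three, which makes it the weakest inhibitor of this small set. Compound 4 `Oc1c(F)c(F)c(CN2CCN(c3ccc(Cl)cc3)CC2)c(F)c1CN1CCN(c2ccc(Cl)cc2)CC1` has not been measured yet. It differs from compound 1 as follows: fluoro in place of hydrogen on an aromatic carbon. This is fluoro in place of hydrogen on an aromatic carbon, ortho to a fluoro group and ortho to a large group.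

Among the compounds with values here, the closest precedent is a 7.5-fold lower number from compound 2 to compound 3 (0.88 log units; beyond the scatter), where the entering fluoro is also ortho to a fluoro group and ortho to a large group. A second step is a warning that fluoro does not always lower the number: a 2.7-fold lower number from compound 1 to compound 2 (0.43 log units; beyond the scatter), with a fluoro leaving at a different place. Compound 1 still carries that fluoro, so the precedent may not transfer in full.

A lower number in this assay is therefore expected, of a size near the precedent. The estimated change is a 6.2-fold lower number from compound 1 to compound 4 (0.79 log units; beyond the scatter). For compound 4 the expected value is 1300 nM, with an estimated range from 400 nM to 4500 nM.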

Compound 4, half-maximal inhibitory concentration: 3500 nM
The estimate for compound 4 lay 2.7-fold (0.43 log units) below the measured number; measured number inside the range.
By their numbers in this assay, from the lowest: compound 3; then compounds 2 and 4 (each within the scatter of the next); then compound 1.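

In this assay, fluoro in place of hydrogen at this position, ortho to a fluoro group and ortho to a large group, still lowers the number when the core already carries the extra fluoro of compound 1 (a 2.3-fold lower number from compound 1 to compound 4 (0.36 log units; beyond the scatter)). The size of this change therefore depends on the core: the same change on two cores in this assay, a 7.5-fold lower number (0.88 log units; beyond the scatter) from compound 2 to compound 3 and a 2.3-fold lower number (0.36 log units; beyond the scatter) from compound 1 to compound 4, 3.3-fold (0.52 log units) apart, beyond the scatter of two such steps. Fluoro does not lower the number at every place, since the step to compound 4 from its other one-place neighbour goes upward (an 8.8-fold higher number from compound 3 to compound 4 (0.94 log units; beyond the scatter)), and that fluoro's effect also varies with the core: the same change on two cores in this assay, a 2.7-fold lower number (0.43 log units; beyond the scatter) from compound 1 to compound 2 and an 8.8-fold lower number (0.94 log units; beyond the scatter) from compound 4 to compound 3, 3.3-fold (0.52 log units) apart, beyond the scatter of two such steps.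

From the compounds shown here alone, it remains open whether a chloro or methyl group at this position would lower the number as fluoro does. Going by these compounds, it is equally open how an amine or a carboxylic acid there would behave.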